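A few compounds are considered here, and "the series" means these few. Any claim that something is new, unique, unknown or untested is made for them only; others in the source may bear on it.

Measured so far:
- compound 1, `COc1ccc(NC(=O)/C=C/C(=O)N2C/C(=C\c3ccc([N+](=O)[O-])cc3)C(=O)/C(=C/c3ccc([N+](=O)[O-])cc3)C2)cc1`: 760 nM
- compound 2, `O=C(/C=C/C(=O)N1C/C(=C\c2ccccc2)C(=O)/C(=C/c2ccccc2)C1)Nc1ccc(Cl)c(Cl)c1`: 350 nM
- compound 3, `O=C(/C=C/C(=O)N1C/C(=C\c2ccccc2)C(=O)/C(=C/c2ccccc2)C1)Nc1ccc([N+](=O)[O-])cc1`: 40000 nM

In a functional assay on CCRF-CEM cells (Homo sapiens) for cytotoxicity (a higher number here means a weaker inhibitor, a lower number a stronger inhibitor), compound 3 stands highest of the three numbers: compound 1 sits a good way below it, and compound 2 further still. For the measured compounds named here, the one measured step that leads into compound 3, a 110-fold higher number from compound 2 to compound 3 (2.06 log units; beyond the scatter), is large and beyond the scatter, and it comes from a change at the same amide nitrogen that is now altered again.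

Compound 4, `Cc1cccc(C)c1NC(=O)/C=C/C(=O)N1C/C(=C\c2ccccc2)C(=O)/C(=C/c2ccccc2)C1`, differs from compound 3 in one place: 2,6-dimethylphenyl in place of 4-nitrophenyl on an amide-type nitrogen. Going by the values given here, only the step from compound 2 to compound 3 bears directly on this change, and it shows that putting 4-nitrophenyl onto this nitrogen moved the number up sharply; removing it again, for another aryl group, is therefore expected to move the number back down by a large amount, though the dimethylphenyl group itself has no measured counterpart here, so the size is uncertain.

Compound 4 is thus estimated at 1000 nM in this assay, within 200 nM to 6000 nM, an expected step of a 40-fold lower number from compound 3 to compound 4 (1.60 log units; beyond the scatter).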

Compound 4, half-maximal inhibitory concentration: 7400 nM
Beside the measured number, compound 4's estimate is 7.4-fold (0.87 log units) below it; measured number above the stated range.
By their numbers in this assay, from the lowest: compound 2; then compound 1; then compound 4; then compound 3.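

In this assay, moving away from 4-nitrophenyl on the amide-type nitrogen brings a 5.4-fold lower number from compound 3 to compound 4 (0.73 log units; beyond the scatter), yet the 2,6-dimethylphenyl group does not recover the level set by 3,4-dichlorophenyl, as a 21-fold higher number from compound 2 to compound 4 (1.33 log units; beyond the scatter) shows. With the rest of the molecule unchanged, the three aryl groups at this place therefore give three clearly separated numbers, and leaving 4-nitrophenyl behind is not enough on its own to reach the number of compound 2. Nothing available here explains this order.

Going by these compounds, it remains open whether the number at this nitrogen depends on the two methyl groups themselves or on where they sit, which a comparison with 4-methylphenyl or plain phenyl could address. Also open, on these data alone, are how a cyclohexyl group would fare here and whether the same order of aryl groups holds on the core of compound 1.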